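Methyl in Place of Hydroxy: Estimating Compound 3

The compounds below may be only part of what the source reports. "The series", "measured", "known", "first", "only" and "open" are said of these compounds alone.

Compound 1, `Cc1cc(O)nc(NC(=S)NC(=O)c2c(-c3ccc(Cl)cc3Cl)noc2C)n1`, was tested in a functional assay on the whole organism for inhibition, with Digitaria ciliaris as the target, with a stated time of 72 h, tested at 100 mg/L (a higher number here means more inhibition of growth at the concentration tested, a lower number less inhibition of growth), where compound 1 gives 49.3%. Compound 2, `Cc1onc(-c2ccc(Cl)cc2Cl)c1C(=O)/N=c1/nc2nc(Cl)cc(C)n2s1`, gives 68.1% in this assay. Of these two numbers, compound 1 stands lowest, and compound 2 lies higher by a margin beyond the usual scatter. Among the measured compounds shown here, compound 2 differs from compound 1 in more than one place, so no single step between measured compounds is available to guide an estimate.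

Compound 3, `Cc1cc(C)nc(NC(=S)NC(=O)c2c(-c3ccc(Cl)cc3Cl)noc2C)n1`, is the next compound to be measured. It differs from compound 1 in one place: methyl in place of hydroxy on an aromatic carbon. For the measured compounds named here, with no measured step of this kind to lean on, the change from compound 1 to compound 3 is expected to stay within the scatter, in either direction. Compound 3 is therefore estimated at 52%, with a range from 28% to 76%, which means an expected step of a number 2.7 percentage points higher from compound 1 to compound 3 (within the scatter).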

Compound 3, percent growth inhibition at one concentration: 61.4%
For compound 3 the middle estimate is 9.4 percentage points below the measured one, and the stated range covers the measured number.
By their numbers in this assay, from the lowest: compound 1; then compounds 3 and 2 (each within the scatter of the next).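

In this assay, among the compounds shown here, the change from 4-hydroxy-6-methylpyrimidin-2-yl to 4,6-dimethylpyrimidin-2-yl gives a number 12.1 percentage points higher from compound 1 to compound 3 (beyond the scatter) and provides the first comparison of compounds that differ in only one place. It shows that the group at this position matters to growth inhibition: hydroxy, with one hydrogen-bond donor and one acceptor, can give way to methyl, with neither, and the reading does not fall. No measurement at hand explains why the number rises.

This single step cannot separate the effect of losing hydroxy from that of gaining methyl. Also open, as far as these compounds go, is how an amine, a methoxy group or a longer chain such as ethyl would read on this same aromatic carbon, and whether the step would hold on a different core.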